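This account rests on a few compounds, and the source may have more. Where it says the series, first, only, none or still open, it means among the compounds named here.

The study measured an ADME assay on HFL1 cells (Homo sapiens) for cytotoxicity (on this read-out higher numbers stand for weaker inhibition and lower numbers for stronger inhibition), on two compounds. Compound 1 `CCc1cnc(N2CCC(c3nc(COc4ccc(-n5cnnn5)cc4)cs3)CC2)nc1` gives only a limit of this assay, > 100000 nM. Compound 2 `CCc1cnc(N2CCC(c3nc(COc4ccc(/C=C5\CC(=O)NC5=O)cc4F)cs3)CC2)nc1` also gives only a limit of this assay, > 100000 nM. Where compound 2 stands is told by the limit of > 100000 nM in this assay, at which 2 of the 2 values shown sit: at the limit, as compound 1 does. Compound 3 `CCc1cnc(N2CCC(c3nc(COc4ccc(/C=C5\CC(=O)NC5=O)cc4C)cs3)CC2)nc1` differs from compound 2 by methyl in place of fluoro on an aromatic carbon. Going by the values given here, no step between measured compounds is available for this assay. The step that the expectation means, a number no higher from compound 2 to compound 3 (the limit leaves the size open), is expected to lie within the scatter. Compound 3 is expected to give 100000 nM in this assay, with a range from 50000 nM to 200000 nM.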

Compound 3, half-maximal inhibitory concentration: > 100000 nM
Compound 3 ended at the assay's limit (the forecaster's own chance of this, stated with the estimate: 90%); the middle value sits exactly at the limit.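

No step can be read from compound 2 to compound 3, since both values are limits in this assay: the limit of > 100000 nM in this assay, at which 3 of the 3 values shown sit. The compounds shown leave open whether methyl in place of fluoro on an aromatic carbon changes the result in this assay at all.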